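Phenyl to Isopentyl on the Triazole: Will Anything Change?

The compounds below may be only part of what the source reports. "The series", "measured", "known", "first", "only" and "open" are said of these compounds alone.

Compound 1 `O=C(c1cc(-n2cc(-c3ccccc3)nn2)ccc1O)N1CCCCC1` gives > 20000 nM in a functional assay on RAW264.7 cells (Mus musculus) for inhibition, read by Griess assay, with a stated time of 20 h (a lower number here means a stronger inhibitor, a higher number a weaker inhibitor), which is a limit of the assay rather than a number.
Compound 2 `CC(C)CCc1cn(-c2ccc(O)c(C(=O)N3CCCCC3)c2)nn1` gives > 20000 nM in this assay, again a limit.
Compound 3 `CCCNC(=O)c1ccc(-n2cc(-c3ccccc3)nn2)cc1O` gives > 20000 nM in this assay, also a limit.

All three measured compounds share one finding: the limit of > 20000 nM in this assay, at which 3 of the 3 values shown sit. The change from compound 1 to compound 2, (isopentyl in place of phenyl on an aromatic carbon), therefore gives a step that the two limits leave unreadable from compound 1 to compound 2. Compound 4 `CCCNC(=O)c1ccc(-n2cc(CCC(C)C)nn2)cc1O` carries exactly the same change relative to compound 3, (isopentyl in place of phenyl on an aromatic carbon), at the same place. The difference between the core of compound 1 and the core of compound 3 is not broken down here.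

Since both limits around the first step leave its size unknown, the same change on the second core offers no reason to expect a readable number. The expected step is a step that the limit leaves unreadable from compound 3 to compound 4, resting on a step that the two limits leave unreadable from compound 1 to compound 2. Compound 4 is expected to give about 30000 nM, most likely between 12000 nM and 100000 nM, and quite probably again only as a limit.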

Compound 4, half-maximal inhibitory concentration: > 20000 nM
Compound 4 ended at the assay's limit; the forecaster's own chance of this, stated with the estimate: 85%; the middle value lies beyond the limit too.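

Within the data shown here, compound 3 and compound 4 both give only a limit, and no step between them can be read. The compounds shown leave open whether either phenyl or isopentyl allows any measurable inhibition in this assay.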